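Methylamino for methyl on a pyrimidine-type core: an estimate

The source may hold more compounds than are shown below. What is called first, only, known or untested is meant among the compounds shown, and "the series" means these compounds.

Of the compounds shown here, three have been measured in a functional assay on the whole organism for inhibition, with Rattus norvegicus as the target, with stated times of 1 h and 3.5 h, at a dose of 100 mg/kg by the oral route; a lower number here means less inhibition, a higher number more inhibition at the dose given (going by the name of the read-out). Compound 1 `Cc1ncc(C)c(-c2ccccc2)n1` gives 12%. Compound 2 `Cc1cncnc1-c1ccncc1` gives 50%. Compound 3 `Cc1ncc(-c2ccccc2)c(C(C)(C)C)n1` gives 22%. Among these three numbers compound 3 stands second highest; its nearest neighbour is compound 1, whose number lies within the scatter of the one for compound 3, so the two cannot be told apart. Compound 2 lies furthest from compound 3, and its higher number stands beyond the scatter, so compound 2 shows more inhibition than compound 3.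

Compound 4 `CNc1ncc(-c2ccccc2)c(C(C)(C)C)n1` has not been measured. It differs from compound 3 in one place: methylamino in place of methyl on an aromatic carbon. Among the compounds with values here, no measured pair of compounds changes in this place, so the account has no step of this kind to lean on; the size of the effect is open.

The step is therefore expected to be small, and in either direction or none beyond the scatter: the account expects a number 6 percentage points higher from compound 3 to compound 4 (within the scatter). Compound 4 is estimated to give 28% in this assay, with a range from 8% to 55%.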

Compound 4, a percentage reported as inhibition, in the whole organism at one dose (the size of the read-out at that dose, not a potency): 37%
For compound 4 the middle estimate is 9 percentage points below the measured one, within the range that was stated.
By their numbers in this assay, from the lowest: compounds 1 and 3 (each within the scatter of the next); then compound 4; then compound 2.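

In this assay, the aromatic carbon between two ring nitrogen atoms turns out to be a place where a change can move the read-out: methylamino in place of methyl gives a number 15 percentage points higher from compound 3 to compound 4 (beyond the scatter). Within the data shown here, this modest step is the first that can be read from a matched pair, and it shows that the read-out at this dose responds to this position while the tert-butyl group and the rest of the shared core stay as they are. Nothing at hand accounts for the step.

The compounds shown leave open whether a plain amine, a dimethylamino group or a longer chain such as ethylamino at this position would give a number like that of compound 4, and whether a methoxy group, which also puts a heteroatom on this carbon, would do the same. They also leave open whether the step carries over to a core without the tert-butyl group, and, with a single dose and a single pair, how the change would look as a potency rather than as a read-out at that dose.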